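Cytotoxicity in the biaryl amide acid series: bromo variant

This account rests on a few compounds, and the source may have more. Where it says the series, first, only, none or still open, it means among the compounds named here.

Compound 3 `CCOc1cccc(-c2ccc(C(=O)N(Cc3cccc(OCCCCCC(=O)O)c3)C(C)C)cc2)c1` is the reference for this step. In an ADME assay on BJ cells (Homo sapiens) for cytotoxicity, read by CellTiter-Glo and resazurin assay, with a stated time of 72 h (a higher number here means that more compound is needed for the effect, a lower number that less compound is needed), compound 3 gives only a limit, > 20800 nM. The two other measured members stand at the same kind of result. Compound 1 `CC(C)N(Cc1cccc(OCCCCCC(=O)O)c1)C(=O)c1ccc(-c2cccc(Oc3ccccc3)c2)cc1` gives a limit in this assay, > 18700 nM. Compound 2 `COc1cccc(-c2ccc(C(=O)N(Cc3cccc(OCCCCCC(=O)O)c3)C(C)C)cc2)c1` likewise gives a limit in this assay, > 20900 nM. Because every value is a limit, the steps a step that the two limits leave unreadable from compound 1 to compound 2, a step that the two limits leave unreadable from compound 1 to compound 3 and a step that the two limits leave unreadable from compound 2 to compound 3 cannot be read; all three compounds sit at the edge of the tested range, as the lines (the limit of > 18700 nM in this assay, at which 1 of the 3 values shown sits), the limit of > 20900 nM in this assay, at which 1 of the 3 values shown sits, and the limit of > 20800 nM in this assay, at which 1 of the 3 values shown sits, record, so compound 3 stands level with the rest as far as the data go.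

Compound 4 `CC(C)N(Cc1cccc(OCCCCCC(=O)O)c1)C(=O)c1ccc(-c2cccc(Br)c2)cc1` differs from compound 3 by bromo in place of ethoxy on an aromatic carbon. Among the measured compounds shown here, no measured step exchanges the ethoxy group at this position for a halogen; the steps from compound 1 to compound 3 and from compound 2 to compound 3 vary the group on the same aromatic oxygen, but both are unreadable between limits. With every measured neighbour at a limit, the step that the limit leaves unreadable from compound 3 to compound 4 is expected to be none beyond the scatter. Compound 4 is therefore estimated to give 21000 nM in this assay, within 10000 nM to 45000 nM, most likely again as a limit.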

Compound 4, half-maximal effective concentration: > 26000 nM
Compound 4 was reported as a limit; the forecaster's own chance of this, stated with the estimate: 80%; middle value at least 1.2-fold (0.09 log units) away from the limit.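

In this assay compound 4 gives only a limit, > 26000 nM. The steps to compound 4 from compound 1, compound 2 and compound 3 cannot be read, as all four values are limits. The compounds shown leave open whether phenoxy, methoxy, ethoxy and bromo on this aromatic carbon differ at all in this assay.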